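Cytotoxicity of two pyrazine hydrazones and an untested analogue

This account rests on a few compounds, and the source may have more. Where it says the series, first, only, none or still open, it means among the compounds named here.

Of the compounds shown here, two have been measured in an ADME assay on J774 cells (Mus musculus) for cytotoxicity, read by MTT assay, with a stated time of 48 h, tested at 150 ug/mL; on this read-out higher numbers stand for a weaker effect at the one concentration tested and lower numbers for a stronger effect. Compound 1 `O=C(N/N=C/c1ccc(Cl)cc1)c1cnccn1` gives 56%, the highest of the two numbers, while compound 2 `O=C(N/N=C/c1ccccc1O)c1cnccn1` gives 0%, a number far below it and beyond the scatter. Compound 3 `CN(C)c1ccc(/C=N/NC(=O)c2cnccn2)cc1` has not been measured; it differs from compound 1 by dimethylamino in place of chloro on an aromatic carbon. For the measured compounds named here, no step between measured compounds involves this change, so the size of the step in this assay cannot be read from the data; a small move in either direction, likely within the scatter, is expected, a number 4 percentage points lower from compound 1 to compound 3 (within the scatter). Compound 3 is therefore estimated at 52%, between 15% and 85%.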

Compound 3, a percentage reported as activity, at one concentration (the size of the read-out at that concentration, not a potency): 89%
For compound 3 the middle estimate is 37 percentage points below the measured one, outside the stated range (above it).
By their numbers in this assay, from the lowest: compound 2; then compound 1; then compound 3.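

In this assay, dimethylamino in place of chloro on an aromatic carbon, para to a large group, gives a number 33 percentage points higher from compound 1 to compound 3 (beyond the scatter), so the read-out at this position responds strongly to this change, towards a weaker effect at the one concentration tested. For the compounds shown here, this single pair is the only step available, so the size of the change rests on it alone. Nothing at hand accounts for a step of this size. On these data alone, it remains open whether a primary amine, a methoxy group or a carboxylic acid at this position would move the number as far. As far as these compounds go, whether dimethylamino would have the same effect elsewhere on the ring also remains open.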